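Adding a second methoxy to compound 2

This account rests on a few compounds, and the source may have more. Where it says the series, first, only, none or still open, it means among the compounds named here.

Measured in a functional assay on HT-29 cells (Homo sapiens) for antiproliferative activity, with a stated time of 72 h (on this read-out higher numbers stand for weaker inhibition and lower numbers for stronger inhibition), so far
- compound 1 `Cn1c(N2N=C(c3ccccc3)CC2c2ccc(Cl)cc2)nc(-c2ccccc2)c(C#N)c1=O` gives 19200 nM
- compound 2 `COc1ccc(C2CC(c3ccccc3)=NN2c2nc(-c3ccccc3)c(C#N)c(=O)n2C)cc1` gives 14700 nM
- compound 3 `Cn1c(N2N=C(c3ccccc3)CC2c2ccc(F)cc2)nc(-c2ccccc2)c(C#N)c1=O` gives 8150 nM

Compound 2 is not separated from either of the other two by more than the scatter, as a 1.3-fold lower number from compound 1 to compound 2 (0.12 log units; within the scatter) and a 1.8-fold lower number from compound 2 to compound 3 (0.26 log units; within the scatter) show. Only a 2.4-fold lower number from compound 1 to compound 3 (0.37 log units; beyond the scatter) clears the scatter, and that step is modest.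

Compound 4 `COc1ccc(C2=NN(c3nc(-c4ccccc4)c(C#N)c(=O)n3C)C(c3ccc(OC)cc3)C2)cc1` differs from compound 2 by methoxy in place of hydrogen on an aromatic carbon. Going by the values given here, no measured step makes this exchange. The three available steps only swap chloro, methoxy and fluoro for one another, so they bear on it indirectly. On that basis, no step beyond the scatter is expected in this assay, and no direction can be favoured. The estimated change is a 1.1-fold lower number from compound 2 to compound 4 (0.05 log units; within the scatter) in size. For compound 4 the estimate is 13000 nM with an expected range of 6000 nM to 30000 nM for the measurement.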

Compound 4, half-maximal inhibitory concentration: 9420 nM
Estimate against measurement, compound 4: 1.4-fold (0.14 log units) above; the range from low to high includes it.
By their numbers in this assay, from the lowest: compounds 3, 4, 2 and 1 (each within the scatter of the next, the first and the last beyond it).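

Phenyl to 4-methoxyphenyl adds a group where the earlier steps only swapped one group for another, and in this assay it gives a 1.6-fold lower number from compound 2 to compound 4 (0.19 log units; within the scatter). This position, para to a large group, therefore accepts a methoxy with no readable change in either direction, at least on compound 2. Nothing available explains this result.

Going by these compounds, whether an amine, a carboxylic acid or a longer chain such as butoxy at this position would give a step beyond the scatter remains open. Fluoro at this position is equally unresolved.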